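The source may hold more compounds than are shown below. What is called first, only, known or untested is meant among the compounds shown, and "the series" means these compounds.

Of the compounds shown here, three built on one shared core have been measured in a functional assay on C6 cells (Rattus norvegicus) for cytotoxicity, read by MTT assay, with a stated time of 24 h, tested at 200 ug/mL; a higher number here means a weaker effect of the compound at the concentration tested, a lower number a stronger effect. Compound 1 `Cc1ccc(-c2cs/c(=N/NC(=O)CSc3nnnn3C)n2-c2ccccc2)cc1` gives 39.7% in this assay. For the measured compounds named here, compound 2 `Cn1nnnc1SCC(=O)N/N=c1/scc(-c2ccc(C#N)cc2)n1-c1ccccc1` gives 28.6%, and the only measured single change, a number 11.1 percentage points lower from compound 1 to compound 2 (beyond the scatter), moves the number down, which here means a stronger effect at the tested concentration. Compound 3 `O=C(CSc1nnnn1-c1ccccc1)N/N=c1/scc(-c2ccccc2)n1-c1ccccc1` gives 22.6%, the lowest of the three numbers; it sits within the scatter of compound 2 but beyond the scatter from compound 1.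

Compound 4 `Cn1nnnc1SCC(=O)N/N=c1/scc(-c2ccccc2)n1-c1ccccc1` is compound 3 with a single change: methyl in place of phenyl on an aromatic nitrogen. Going by the values given here, no measured step touches this place; the one measured step concerns the other aromatic ring and says nothing about the group on the tetrazole nitrogen. Compound 1, with 39.7%, and compound 2, with 28.6%, both carry the methyl, but each also differs from compound 3 in its other ring, so they offer only a loose hint. Only a small shift is therefore expected, of size a number 5.4 percentage points higher from compound 3 to compound 4 (within the scatter), leaning toward a higher number but not beyond the scatter. The estimate for compound 4 is 28%, between 15% and 42%.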

Compound 4, a percentage reported as activity, at one concentration (the size of the read-out at that concentration, not a potency): 26.8%
For compound 4 the middle estimate is 1.2 percentage points above the measured one; the range from low to high includes it.
By their numbers in this assay, from the lowest: compounds 3, 4 and 2 (each within the scatter of the next); then compound 1.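

In this assay, cutting 1-phenyl-1H-tetrazol-5-yl back to 1-methyl-1H-tetrazol-5-yl gives a number 4.2 percentage points higher from compound 3 to compound 4 (within the scatter) and so removes a whole six-membered aromatic ring, leaving a single carbon on that aromatic nitrogen, without a change that can be told from the scatter. Compound 4 also shows what happens with plain hydrogen on the aromatic carbon that carries a substituent in the earlier compounds: replacing cyano gives a number 1.8 percentage points lower from compound 2 to compound 4 (within the scatter) and stays within the scatter, whereas replacing methyl gives a number 12.9 percentage points lower from compound 1 to compound 4 (beyond the scatter) and goes beyond it, so among these three compounds the methyl of compound 1 alone stands apart at that carbon. Nothing measured here explains why these numbers fall as they do.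

The compounds shown carry only phenyl and methyl on the aromatic nitrogen, so the outcome for a longer chain such as butyl, or for a chain ending in an amine or a carboxylic acid, remains open. Also open is whether the swap from phenyl to methyl reads the same when the aromatic carbon carries cyano or methyl rather than hydrogen, and a single tested concentration gives no potency for any of these compounds.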